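The source may report more compounds than this note shows. Statements on the series, on what has been measured and on what is new or still open speak of the compounds shown alone.

Measured so far:
- compound 1 `CC1(C)Cc2c(sc(NC(=O)c3ccccc3O)c2C(N)=O)C(C)(C)O1` — 162 nM
- compound 2 `CC1(C)Cc2c(sc(NC(=O)C3(CO)CC3)c2C(N)=O)C(C)(C)O1` — 1320 nM

In an assay on cells for positive allosteric modulation of Cystic fibrosis transmembrane conductance regulator variant G551D (Homo sapiens), with stated times of 10 min and 2 min, in the presence of a further agent that is not named here (on this read-out lower numbers stand for an effect already at smaller amounts and higher numbers for an effect only at larger amounts of compound), compound 1 gives 162 nM and compound 2 gives 1320 nM. Among the measured compounds shown here, compound 2 stands at the highest of the two numbers; its nearest neighbour is compound 1, and the step of an 8.1-fold higher number from compound 1 to compound 2 (0.91 log units; beyond the scatter) is the only measured change.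

Compound 3 `CC1(C)Cc2c(sc(NC(=O)[C@@H](O)C(C)(C)C)c2C(N)=O)C(C)(C)O1` is the next candidate, differing from compound 2 as follows: 1-hydroxy-2,2-dimethylpropyl in place of 1-(hydroxymethyl)cyclopropyl on a carbonyl carbon. For the measured compounds named here, no measured step covers this exchange of one hydroxyl-bearing aliphatic group for another; the single known step concerns replacement of an aromatic group and does not bear on it directly. Both groups carry one donor and one acceptor, so the working expectation for compound 3 in this assay is a step of a 1.1-fold lower number from compound 2 to compound 3 (0.04 log units; within the scatter), that is none clearly beyond the scatter. Compound 3 is accordingly estimated at 1200 nM, with a range from 450 nM to 3200 nM.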

Compound 3, half-maximal effective concentration: 421 nM
Beside the measured number, compound 3's estimate is 2.9-fold (0.45 log units) above it; measured number below the stated range.
By their numbers in this assay, from the lowest: compound 1; then compound 3; then compound 2.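

In this assay, two hydroxyl-bearing aliphatic groups on a carbonyl carbon whose other neighbour is the amide-type nitrogen are not interchangeable: the change to 1-hydroxy-2,2-dimethylpropyl gives a 3.1-fold lower number from compound 2 to compound 3 (0.50 log units; beyond the scatter), even though the donor and acceptor counts stay the same. This open-chain group closes only part of the gap to 2-hydroxyphenyl, leaving a 2.6-fold higher number from compound 1 to compound 3 (0.41 log units; beyond the scatter), so an aliphatic group can come closer to the aromatic one than compound 2 did without matching it. No measured evidence accounts for either step.

The compounds shown leave open how much of the result in compound 3 depends on its defined stereocentre, which the opposite configuration of 1-hydroxy-2,2-dimethylpropyl would test. They also leave open whether the hydroxyl itself is required, which a plain tert-butyl group or an amine in its place would address.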